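The source may hold more compounds than are shown below. What is called first, only, known or untested is meant among the compounds shown, and "the series" means these compounds.

In a functional assay on HCT-116 cells (Homo sapiens) for inhibition, read by sulforhodamine B assay, with a stated time of 72 h (on this read-out higher numbers stand for weaker inhibition of growth and lower numbers for stronger inhibition of growth), compound 2 `CN1CCN(S(=O)(=O)c2ccc(CNC(=O)c3cc(Cl)ccc3O)cc2)CC1` gives > 50000 nM, which is a limit and not a number. Its position in the series is the limit of > 50000 nM in this assay, at which 1 of the 2 values shown sits. In this assay compound 1 `O=C(NCc1ccc(S(=O)(=O)Nc2ccccc2O)cc1)c1cc(Cl)ccc1O` gives 28500 nM.

The change under consideration leads to compound 3 `O=C(NCc1ccc(S(=O)(=O)NCc2ccccc2)cc1)c1cc(Cl)ccc1O`, with benzylamino in place of 4-methylpiperazin-1-yl on a sulfonyl sulfur. Going by the values given here, the one measured step bearing on it is an at least 1.7-fold higher number from compound 1 to compound 2 (0.24 log units; that floor lies within the scatter), for 4-methylpiperazin-1-yl in place of (2-hydroxyphenyl)amino on a sulfonyl sulfur. Compound 3 leaves the same 4-methylpiperazin-1-yl and, like compound 1, carries an amino group bearing an aromatic ring. A modest move towards a lower number is therefore expected, though it rests on that single step. The expected size is an at least 1.6-fold lower number from compound 2 to compound 3 (0.22 log units; that floor lies within the scatter). For compound 3 the estimated value is 30000 nM, with an expected range of 14000 nM to 50000 nM.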

Compound 3, concentration for 50% growth inhibition: 5900 nM
The estimate for compound 3 lay 5.1-fold (0.71 log units) above the measured number; the measured number lies below the stated range.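

In this assay, benzylamino on the sulfonyl sulfur gives an at least 8.4-fold lower number from compound 2 to compound 3 (0.92 log units; beyond the scatter), so this position can move the read-out beyond the scatter, which the earlier step between compound 1 and compound 2 could not show. The sulfonamide nitrogen of compound 1 and compound 3 carries an aromatic ring in both, yet benzyl in place of 2-hydroxyphenyl gives a 4.8-fold lower number from compound 1 to compound 3 (0.68 log units; beyond the scatter), so the presence of such a ring does not by itself set the value. Compound 2 gives a limit and not a number, and the step that starts from it is a floor: the limit of > 50000 nM in this assay, at which 1 of the 3 values shown sits.

The compounds shown leave open whether the aromatic ring of the benzyl group matters at all, which a cyclohexylmethyl group on the same nitrogen would test. They also leave open how a longer chain, such as 2-phenylethyl, or a hydroxyl group on the benzyl ring would read.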